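Hydroxamic acid in place of carboxylic acid on a cyclopropyl

The source may hold more compounds than are shown below. What is called first, only, known or untested is meant among the compounds shown, and "the series" means these compounds.

Compound 2 `O=C(O)[C@@H]1C[C@H]1c1ccc(NCc2cccc(Oc3ccccc3)c2)cc1` gives 562 nM in a functional assay on CHO cells for agonist activity at Free fatty acid receptor 1 (Homo sapiens) (on this read-out higher numbers stand for an effect only at larger amounts of compound and lower numbers for an effect already at smaller amounts), the highest of the two numbers measured; compound 1 `CC(CC(=O)O)c1ccc(NCc2cccc(Oc3ccccc3)c2)cc1` gives 126 nM, and the step of a 4.5-fold higher number from compound 1 to compound 2 (0.65 log units; beyond the scatter) is modest. Compound 3 `O=C(NO)[C@H]1C[C@@H]1c1ccc(NCc2cccc(Oc3ccccc3)c2)cc1` differs from compound 2 by 2-(hydroxycarbamoyl)cyclopropyl in place of 2-carboxycyclopropyl on an aromatic carbon. Among the compounds with values here, no measured step bears on this exchange: the one step known concerns the ring, not the acid group, so the direction rests on the structures alone. Compound 3 is therefore expected to show a weaker effect by a 2.7-fold higher number from compound 2 to compound 3 (0.43 log units; beyond the scatter), with an estimate of 1500 nM and a range from 400 nM to 6000 nM.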

Compound 3, half-maximal effective concentration: 14.8 nM
Beside the measured number, compound 3's estimate is 100-fold (2.01 log units) above it; measured number below the stated range.
By their numbers in this assay, from the lowest: compound 3; then compound 1; then compound 2.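

In this assay, the group carried on the cyclopropyl ring emerges as a strong lever at this position: 2-(hydroxycarbamoyl)cyclopropyl in place of 2-carboxycyclopropyl gives a large gain (a 38-fold lower number from compound 2 to compound 3 (1.58 log units; beyond the scatter)). This exchange more than makes up for the loss seen on going to the ring, as the new group also surpasses the open-chain acid (an 8.5-fold lower number from compound 1 to compound 3 (0.93 log units; beyond the scatter)). No evidence here accounts for the size of this shift. As far as these compounds go, it remains open whether a hydroxamic acid on the 1-(carboxymethyl)ethyl chain of compound 1 would gain likewise, and whether a primary amide or a tetrazole on the cyclopropyl ring would keep the gain.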